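Ethoxy to butoxy on the compound 1 core

A few compounds are considered here, and "the series" means these few. Any claim that something is new, unique, unknown or untested is made for them only; others in the source may bear on it.

In a functional assay on L1210 (1565) cells (Mus musculus) for cytotoxicity (on this read-out lower numbers stand for an effect already at smaller amounts and higher numbers for an effect only at larger amounts of compound), compound 1 (`CCOc1cc(-c2ccccc2)nc2ccccc12`) gives > 10 ug/mL as its reading, which is a limit of the assay. Among the compounds with values here, compound 2 (`Oc1cc(-c2ccccc2)nc2ccc(Cl)cc12`) gives 0.5 ug/mL as its reading and is the only compound with a number so far. Compound 3 (`COCOc1ccc(-c2cc(=O)c3ccccc3n2C)cc1`) gives > 10 ug/mL as its reading, again a limit. Within the data shown here, compound 1 therefore stands at the limit of > 10 ug/mL in this assay, at which 2 of the 3 values shown sit, and offers no exact number to step from.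

The change to compound 4 (`CCCCOc1cc(-c2ccccc2)nc2ccccc12`) is ethyl in place of hydrogen on a saturated chain carbon, two bonds along the chain from an oxygen on an aromatic ring and reads as ethoxy to butoxy. Among the measured compounds shown here, no measured pair shows this change. The expectation rests on compound 1 with > 10 ug/mL as its limit, and no step beyond the scatter is expected in either direction in this assay for this change. The expected step is a number no higher from compound 1 to compound 4 (the limit leaves the size open) as an estimate. For compound 4 the estimate is 10 ug/mL with an expected range of 3 ug/mL to 30 ug/mL. An outcome that is only a limit of the assay is also expected to be quite likely.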

Compound 4, half-maximal effective concentration: > 10 ug/mL
Compound 4: a limit, no number; the forecaster's own chance of this, stated with the estimate: 60%; the middle value lies on the limit itself.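

Compound 1 and compound 4 both stand at a limit in this assay, so no step between them can be read: the limit of > 10 ug/mL in this assay, at which 3 of the 4 values shown sit.

The compounds shown leave open whether ethoxy and butoxy on the shared core differ at all in this assay.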